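Working notes: from compound 2 to compound 3

The compounds below may be only part of what the source reports. "The series", "measured", "known", "first", "only" and "open" are said of these compounds alone.

- compound 1 `Cn1cc(C2=C(c3nn(CCCn4ccnc4)c4ncccc34)C(=O)NC2=O)c2ccccc21`: 13800 nM
- compound 2 `Cn1cc(C2=C(c3nn(CCCN4CCCCC4)c4ncccc34)C(=O)NC2=O)c2ccccc21`: 5960 nM

In a functional assay on K562 cells (Homo sapiens) for antiproliferative activity, read by MTT assay, with a stated time of 48 h (on this read-out higher numbers stand for weaker inhibition and lower numbers for stronger inhibition), compound 2 has the lower of the two numbers. Compound 3 `Cn1cc(C2=C(c3nn(CCn4ccnc4)c4ncccc34)C(=O)NC2=O)c2ccccc21` carries 2-(1H-imidazol-1-yl)ethyl in place of 3-(piperidin-1-yl)propyl (1H-imidazol-1-yl in place of (piperidin-1-yl)methyl on a saturated chain carbon, two bonds along the chain from an aromatic nitrogen). Going by the values given here, the one measured step bearing on this is a 2.3-fold lower number from compound 1 to compound 2 (0.36 log units; beyond the scatter), a modest change that exchanges the same two rings in the opposite direction. Among the compounds with values here, no measured pair isolates the shorter chain. A similarly modest move to a higher number is therefore expected in this assay, an expected step of a 2.0-fold higher number from compound 2 to compound 3 (0.30 log units; within the scatter). The estimated value for compound 3 is 12000 nM, with an expected range of 5000 nM to 30000 nM.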

Compound 3, half-maximal inhibitory concentration: > 100000 nM
Compound 3 gave a limit, no number (the forecaster's own chance of this, stated with the estimate: 5%); middle value at least 8.3-fold (0.92 log units) from the limit.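

Compound 3 gives only a limit of the assay in this assay, not a number: the limit of > 100000 nM in this assay, at which 1 of the 3 values shown sits. With the ring kept, 1H-imidazol-1-yl in place of (1H-imidazol-1-yl)methyl gives an at least 7.2-fold higher number from compound 1 to compound 3 (0.86 log units; beyond the scatter), so chain length at this position counts, which compounds 1 and 2 could not show. With ring and chain both changed, the step is an at least 16-fold higher number from compound 2 to compound 3 (1.22 log units; beyond the scatter).

On these data alone, how a 2-(piperidin-1-yl)ethyl chain reads remains open, which would separate chain length from ring in the piperidine series. As far as these compounds go, a longer chain, or a morpholine or dimethylamine at the chain end, is also open.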